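The source may hold more compounds than are shown below. What is called first, only, known or untested is meant among the compounds shown, and "the series" means these compounds.

Measured compounds:
compound 1 `O=C(NCCNS(=O)(=O)c1ccc(-c2ccccc2OCc2cccc(O)c2)s1)Nc1cc(Cl)cc(Cl)c1` with 2800 nM in a functional assay on HL-60 cells (Homo sapiens) for inhibition, read by CCK-8 assay, with a stated time of 48 h; a lower number here means a stronger inhibitor, a higher number a weaker inhibitor;
compound 2 `CC(C)c1ccc(Oc2ccc(O)c(O)c2)c(-c2ccsc2S(=O)(=O)NCCNC(=S)Nc2ccc([N+](=O)[O-])cc2)c1` with 8800 nM in this assay;
compound 3 `O=[N+]([O-])c1ccc(NC(=S)NCCNS(=O)(=O)c2ccc(-c3ccccc3OCc3cccc(O)c3)s2)cc1` with 10800 nM in this assay.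

Compounds 1 and 3 share a core and differ in one place: a group of 11 heavy atoms (7 carbon, 1 nitrogen, 1 oxygen, 2 chlorine; one six-membered aromatic ring of carbon only) in place of a group of 12 heavy atoms (7 carbon, 2 nitrogen, 2 oxygen, 1 sulfur; one six-membered aromatic ring of carbon only), on an amine nitrogen. That change brought a 3.9-fold lower number from compound 3 to compound 1 (0.59 log units; beyond the scatter). Compound 2 and compound 3 have different cores; how the two cores differ is not broken down here, and their values lie within the scatter of each other. Compound 4 `CC(C)c1ccc(Oc2ccc(O)c(O)c2)c(-c2ccsc2S(=O)(=O)NCCNC(=O)Nc2cc(Cl)cc(Cl)c2)c1` is not yet measured; it carries the same change on the core of compound 2: a group of 11 heavy atoms (7 carbon, 1 nitrogen, 1 oxygen, 2 chlorine; one six-membered aromatic ring of carbon only) in place of a group of 12 heavy atoms (7 carbon, 2 nitrogen, 2 oxygen, 1 sulfur; one six-membered aromatic ring of carbon only), on an amine nitrogen. The place is the same in both pairs, so this is the same change. Because compound 1 showed a 3.9-fold lower number from compound 3 to compound 1 (0.59 log units; beyond the scatter) on a related core, a step of similar size is expected from compound 2, namely a 3.4-fold lower number from compound 2 to compound 4 (0.53 log units; beyond the scatter), though a single earlier step is a thin basis. Compound 4 is therefore estimated at 2600 nM in this assay, expected to fall between 1000 nM and 7000 nM.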

Compound 4, half-maximal inhibitory concentration: 6500 nM
The estimate for compound 4 lay 2.5-fold (0.40 log units) below the measured number, within the range that was stated.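

In this assay, putting (3,5-dichlorophenyl)carbamoyl on the amine nitrogen of the core of compound 2 gave a 1.4-fold lower number from compound 2 to compound 4 (0.13 log units; within the scatter), a step that cannot be told from repeat-measurement noise. Set beside the earlier step, it does not match: the same change on two cores in this assay, a 3.9-fold lower number (0.59 log units; beyond the scatter) from compound 3 to compound 1 and a 1.4-fold lower number (0.13 log units; within the scatter) from compound 2 to compound 4, 2.8-fold (0.45 log units) apart, beyond the scatter of two such steps In these two pairs, then, the size of the step did not carry from one core to the other, but two pairs cannot show which feature of the cores matters or how a third core would respond.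

It remains open which part of the exchanged group accounts for the step, something a thiocarbonyl bearing the same dichlorophenyl ring could separate. A longer chain on the amine nitrogen is also untested in what is shown here.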